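Adding Fluorine to a Compound Already at the Limit

The source may report more compounds than this note shows. Statements on the series, on what has been measured and on what is new or still open speak of the compounds shown alone.

Compound 1 `CO[C@@H]1[C@H](N(C)c2ncc(-c3c[nH]c4ccc(F)cc34)s2)C[C@H]2O[C@]1(C)n1c3ccccc3c3c4c(c5c6ccccc6n2c5c31)C(=O)NC4`: in a functional assay on K562 cells (Homo sapiens) for antiproliferative activity, read by CellTiter-Glo, with a stated time of 72 h (on this read-out higher numbers stand for weaker inhibition and lower numbers for stronger inhibition), compound 1 gives > 10000 nM
Compound 2 `CO[C@@H]1[C@H](N(C)c2ncc(-c3c[nH]c4ccc(Cl)cc34)s2)C[C@H]2O[C@]1(C)n1c3ccccc3c3c4c(c5c6ccccc6n2c5c31)C(=O)NC4`: in this assay compound 2 gives > 10000 nM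
Compound 3 `CO[C@@H]1[C@H](N(C)c2ncc(-c3c[nH]c4ccccc34)s2)C[C@H]2O[C@]1(C)n1c3ccccc3c3c4c(c5c6cc(Cl)ccc6n2c5c31)C(=O)NC4`: in this assay compound 3 gives > 10000 nM

Each of these values is a limit of this assay and not a number. Compound 3 therefore stands at the limit, and so do the other two, which is what the limit of > 10000 nM in this assay, at which 3 of the 3 values shown sit, records. Because both ends of a step that the two limits leave unreadable from compound 1 to compound 2 are limits, that step cannot be read. Compound 4 `CO[C@@H]1[C@H](N(C)c2ncc(-c3c[nH]c4ccc(F)cc34)s2)C[C@H]2O[C@]1(C)n1c3ccccc3c3c4c(c5c6cc(Cl)ccc6n2c5c31)C(=O)NC4` differs from compound 3 by fluoro in place of hydrogen on an aromatic carbon. Among the compounds with values here, no measured step tracks this exact change, but every measured compound sits at the limit, including compound 1, which already carries the 5-fluoro-1H-indol-3-yl group. The expected step that the limit leaves unreadable from compound 3 to compound 4 is therefore none beyond the scatter. Compound 4 is estimated at 15000 nM with a range of 5000 nM to 50000 nM, most likely reported again only as a limit.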

Compound 4, half-maximal inhibitory concentration: > 10000 nM
Compound 4: a limit, no number; the forecaster's own chance of this, stated with the estimate: 85%; the middle value lies beyond the limit too.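

In this assay compound 4 gives > 10000 nM, which is a limit and not a number. The steps to compound 4 from compound 1 and from compound 3 therefore cannot be read. The compounds shown leave open whether fluoro or chloro changes the activity at all, with every value at the same limit: the limit of > 10000 nM in this assay, at which 4 of the 4 values shown sit.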